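Piperidin-4-yl replaces a long chain at the assay limit

The source may hold more compounds than are shown below. What is called first, only, known or untested is meant among the compounds shown, and "the series" means these compounds.

- compound 1 `CC(C)COC(=O)NCCOc1ccc(Cl)cc1C(=O)N[C@H](C(=O)Nc1ccc([N+](=O)[O-])cc1Cl)C(C)C` gives 10100 nM
- compound 2 `CC(C)[C@H](NC(=O)c1cc(Cl)ccc1OCCCN)C(=O)Nc1ccc([N+](=O)[O-])cc1Cl` gives > 10000 nM (a limit, not a number)
- compound 3 `CC(C)[C@H](NC(=O)c1cc(Cl)ccc1OCCCCNC(=O)OC(C)(C)C)C(=O)Nc1ccc([N+](=O)[O-])cc1Cl` gives > 10000 nM (a limit, not a number)

In a functional assay on MCF7 cells (Homo sapiens) for inhibition, read by MTT assay, with a stated time of 72 h (a higher number here means a weaker inhibitor, a lower number a stronger inhibitor), compound 3 gives only a limit, > 10000 nM and no number. What the series shows is the limit of > 10000 nM in this assay, at which 2 of the 3 values shown sit, and that is a limit too. Among the compounds with values here, compound 1 gives the sole number, 10100 nM and so offers the only firm reading.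

Compound 4 `CC(C)[C@H](NC(=O)c1cc(Cl)ccc1OC1CCNCC1)C(=O)Nc1ccc([N+](=O)[O-])cc1Cl` differs from compound 3 by one change: piperidin-4-yl in place of 4-((tert-butoxycarbonyl)amino)butyl on an oxygen on an aromatic ring.

Three measured steps alter the same side chain: a step that the limit leaves unreadable from compound 1 to compound 2 and a step that the limit leaves unreadable from compound 1 to compound 3 and a step that the two limits leave unreadable from compound 2 to compound 3 and none of them has a size that can be read. They give no direction for the new change, so no step beyond the scatter can be foreseen. The expected step is a number no higher from compound 3 to compound 4 (the limit leaves the size open) in this assay and that expectation is a weak one. For compound 4 the estimated value is 10000 nM with an expected range from 3500 nM to 30000 nM and the result may well be a limit again.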

Compound 4, half-maximal inhibitory concentration: > 10000 nM
Compound 4 gave a limit, no number (the forecaster's own chance of this, stated with the estimate: 65%); the middle value lies on the limit itself.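

In this assay compound 4 gives > 10000 nM, a limit and not a number. None of its steps from compound 1, compound 2 or compound 3 can be read, and the series stays where it was: the limit of > 10000 nM in this assay, at which 3 of the 4 values shown sit. The compounds shown leave open how compound 2, compound 3 and compound 4 rank against one another and against compound 1.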